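Chlorophenyl in Place of Dimethylaminophenyl on the Unmethylated Core

This account rests on a few compounds, and the source may have more. Where it says the series, first, only, none or still open, it means among the compounds named here.

Measured compounds:
compound 1, `Cc1ccc2[nH]c(-c3ccc(-c4ccc(-c5ccc(N(C)C)cc5)cc4)cc3)nc2c1`, 3230 nM
compound 2, `Cc1ccc2[nH]c(-c3ccc(-c4ccc(-c5cccc(Cl)c5)cc4)cc3)nc2c1`, 2510 nM
compound 3, `CN(C)c1ccc(-c2ccc(-c3ccc(-c4nc5ccccc5[nH]4)cc3)cc2)cc1`, 100000 nM

In a functional assay on DWD cells (Homo sapiens) for inhibition, read by sulforhodamine B assay (a lower number here means a stronger inhibitor of growth, a higher number a weaker inhibitor of growth), compound 1 gives 3230 nM. Compound 2 differs from compound 1 by 3-chlorophenyl in place of 4-(dimethylamino)phenyl on an aromatic carbon, and the step of a 1.3-fold lower number from compound 1 to compound 2 (0.11 log units; within the scatter). Compound 3 shares the terminal group of compound 1 but carries a different core, the two cores differing by hydrogen in place of methyl on an aromatic carbon; the step of a 31-fold higher number from compound 1 to compound 3 (1.49 log units; beyond the scatter), so compound 3 gives 100000 nM.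

Compound 4, `Clc1cccc(-c2ccc(-c3ccc(-c4nc5ccccc5[nH]4)cc3)cc2)c1`, is not yet measured. It differs from compound 3 by 3-chlorophenyl in place of 4-(dimethylamino)phenyl on an aromatic carbon, the same change that was made from compound 1 to compound 2, and it occurs twice among these compounds. Since that earlier step a 1.3-fold lower number from compound 1 to compound 2 (0.11 log units; within the scatter), a similarly small step is expected on the core of compound 3 as well, so that a 1.3-fold lower number from compound 3 to compound 4 (0.10 log units; within the scatter) is the expected outcome. Compound 4 is therefore estimated at 80000 nM, within a range from 30000 nM to 200000 nM.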

Compound 4, concentration for 50% growth inhibition: 100000 nM
Compound 4: the middle estimate sits 1.3-fold (0.10 log units) below what was measured, within the range that was stated.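

In this assay, the step from 4-(dimethylamino)phenyl to 3-chlorophenyl comes out as no change at the digits printed from compound 3 to compound 4 (within the scatter), and the two cores agree on this change: the same change on two cores in this assay, a 1.3-fold lower number (0.11 log units; within the scatter) from compound 1 to compound 2 and no change at the digits printed (within the scatter) from compound 3 to compound 4, 1.3-fold (0.11 log units) apart, within the scatter of two such steps

The removal of the methyl group reads the same way, with a 40-fold higher number from compound 2 to compound 4 (1.60 log units; beyond the scatter) standing beside the earlier step on the other terminal group: the same change on two cores in this assay, a 31-fold higher number (1.49 log units; beyond the scatter) from compound 1 to compound 3 and a 40-fold higher number (1.60 log units; beyond the scatter) from compound 2 to compound 4, 1.3-fold (0.11 log units) apart, within the scatter of two such steps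

Within these four compounds, the two changes therefore behave as if each acted on its own, but two cores and two terminal groups do not show that this holds more widely, and they give no reason why the terminal group counts for so little while the methyl group counts for so much.

As far as these compounds go, it remains open whether the same small step would appear with a terminal phenyl carrying an amine on a longer chain or a carboxylic acid. From the compounds shown here alone, it is equally open how a methoxy group or a chlorine in place of the methyl group would compare on the shared core.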